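Extending the Chain on a Urea Acyltransferase Inhibitor

The source may hold more compounds than are shown below. What is called first, only, known or untested is meant among the compounds shown, and "the series" means these compounds.

Three ureas sharing one core have been measured in an assay on isolated protein for inhibition of acyl-CoA:cholesterol acyltransferase (Oryctolagus cuniculus); a lower number here means a stronger inhibitor, a higher number a weaker inhibitor. Compound 1 `CCCc1ccc(NC(=O)Nc2c(C(C)C)cccc2C(C)C)cc1` gives 38 nM. Compound 2 `CCc1ccc(NC(=O)Nc2c(C(C)C)cccc2C(C)C)cc1` gives 100 nM, the highest of the three numbers. Compound 3 `CCCCCCCCCCCCc1ccc(NC(=O)Nc2c(C(C)C)cccc2C(C)C)cc1` gives 15 nM, the lowest. The step from compound 1 to compound 2 is a 2.6-fold higher number from compound 1 to compound 2 (0.42 log units; beyond the scatter), the step from compound 1 to compound 3 is a 2.5-fold lower number from compound 1 to compound 3 (0.40 log units; beyond the scatter), and the step from compound 2 to compound 3 is a 6.7-fold lower number from compound 2 to compound 3 (0.82 log units; beyond the scatter).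

Compound 4 `CCCCCCCCCc1ccc(NC(=O)Nc2c(C(C)C)cccc2C(C)C)cc1` is not yet measured. It differs from compound 2 by heptyl in place of hydrogen on a saturated chain carbon, two bonds along the chain from an aromatic carbon. This change lies on the same chain that separates compound 2 from compound 1 and from compound 3, and both of those steps lowered the number in this assay beyond the scatter, the smaller addition giving the smaller step and the larger addition the larger step. The addition in compound 4 sits between those two in size, so the expected step is also a lowering, somewhere between the two measured ones, and my estimate for the step from compound 2 to compound 4 in this assay is a 5.0-fold lower number from compound 2 to compound 4 (0.70 log units; beyond the scatter). On that basis compound 4 is estimated to give 20 nM in this assay, with a likely range from 8 nM to 50 nM.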

Compound 4, half-maximal inhibitory concentration: 9 nM
The estimate for compound 4 lay 2.2-fold (0.35 log units) above the measured number; measured number inside the range.
By their numbers in this assay, from the lowest: compounds 4 and 3 (each within the scatter of the next); then compound 1; then compound 2.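

In this assay, among the compounds shown here, heptyl in place of hydrogen on this saturated chain carbon gives an 11-fold lower number from compound 2 to compound 4 (1.05 log units; beyond the scatter) and is the only step in this small series printed as large, while hexyl added further out on the chain gives a 4.2-fold lower number from compound 1 to compound 4 (0.63 log units; beyond the scatter) and is also beyond the scatter. For the compounds shown here, the new compound also shows that the chain does not have to be as long as the one in compound 3 to reach this range of numbers: taking propyl off the end of that longer chain gives a 1.7-fold lower number from compound 3 to compound 4 (0.22 log units; within the scatter) and stays within the scatter, so these two compounds cannot be told apart, and the steady fall seen among the shorter chains does not clearly continue past this length. Nothing available explains why lengthening the chain changes the number in this way.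

The compounds shown leave open whether a still longer chain than the one in compound 3 would hold the number in this range or lose ground. They also leave open whether a branched chain, or a chain ending in an amine or a carboxylic acid, would behave like the plain chains here.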